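Fluoro for Methyl Tested Across Two Related Cores

The source may hold more compounds than are shown below. What is called first, only, known or untested is meant among the compounds shown, and "the series" means these compounds.

Compound 1 `Cc1ccc(-c2ccnc3c2c(-c2ccccc2)nn3-c2ccccc2)cc1` gives 10700 nM in a functional assay on HepG2 cells (Homo sapiens) for inhibition, read by MTT assay, with a stated time of 48 h; a higher number here means a weaker inhibitor, a lower number a stronger inhibitor.
Compound 2 `Fc1ccc(-c2ccnc3c2c(-c2ccccc2)nn3-c2ccccc2)cc1` gives 1570 nM in this assay.
Compound 3 `Cc1ccc(C(=O)C=CNc2cc(-c3ccccc3)nn2-c2ccccc2)cc1` gives 7320 nM in this assay.

Compounds 1 and 2 share one core and differ in a single place:

fluoro in place of methyl on an aromatic carbon

That change made a 6.8-fold lower number from compound 1 to compound 2 (0.83 log units; beyond the scatter). Compound 3 carries a different core; how the two cores differ is not broken down here. In this assay compound 3 stands within the scatter of compound 1 and beyond the scatter of compound 2, whose number is lower.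

Compound 4 `O=C(C=CNc1cc(-c2ccccc2)nn1-c1ccccc1)c1ccc(F)cc1` has not yet been measured. It differs from compound 3 by the same change, at the same place:

fluoro in place of methyl on an aromatic carbon

A lower number for compound 4 is expected because the same change earlier gave a 6.8-fold lower number from compound 1 to compound 2 (0.83 log units; beyond the scatter); since the core is not the same, a somewhat smaller step is expected. For compound 4 the expected step is a 2.9-fold lower number from compound 3 to compound 4 (0.47 log units; beyond the scatter). Compound 4 is therefore estimated at 2500 nM, with a likely range from 900 nM to 7500 nM.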

Compound 4, half-maximal inhibitory concentration: 59900 nM
Beside the measured number, compound 4's estimate is 24-fold (1.38 log units) below it, outside the stated range (above it).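

In this assay, fluoro in place of methyl on an aromatic carbon gave an 8.2-fold higher number from compound 3 to compound 4 (0.91 log units; beyond the scatter), which runs opposite to the step seen on the core of compound 1. The size and direction of this change therefore did not carry from one core to the other, and the two steps stand clearly apart: the same change on two cores in this assay, a 6.8-fold lower number (0.83 log units; beyond the scatter) from compound 1 to compound 2 and an 8.2-fold higher number (0.91 log units; beyond the scatter) from compound 3 to compound 4, 56-fold (1.75 log units) apart, beyond the scatter of two such steps This shows that, for these two pairs, the outcome of the change depends on the core that carries it, but it does not show which feature of the cores accounts for the reversal, and two pairs give no rule for the wider series.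

The compounds shown leave open whether a different group in the same place, such as chloro, methoxy or an amine, would also split between the two cores. They also leave open how either core behaves with a plain unsubstituted phenyl there, which would show whether methyl or fluoro drives each step.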